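The source may report more compounds than this note shows. Statements on the series, on what has been measured and on what is new or still open speak of the compounds shown alone.

In an assay on isolated protein for inhibition of biotin--protein ligase (Homo sapiens), read by scintillation counting, with a stated time of 10 min (a higher number here means a weaker inhibitor, a lower number a stronger inhibitor), compound 3 `O=C1N[C@H]2[C@H](CS[C@H]2CCCCCc2cn(Cc3ccc(I)cc3)nn2)N1` gives only a limit of the assay, > 16000 nM. Compound 1 `O=C1N[C@H]2[C@H](CS[C@H]2CCCCCc2cn(Cc3cccc(O)c3)nn2)N1` likewise gives only a limit, > 16000 nM. Compound 2 `O=C1N[C@H]2[C@H](CS[C@H]2CCCCCc2cn(Cc3ccc(C(F)(F)F)cc3)nn2)N1` also gives only a limit, > 16000 nM. This is summarised by the limit of > 16000 nM in this assay, at which 3 of the 3 values shown sit. The measured steps a step that the two limits leave unreadable from compound 1 to compound 2, a step that the two limits leave unreadable from compound 1 to compound 3 and a step that the two limits leave unreadable from compound 2 to compound 3 therefore have no readable size or direction. Compound 4 `O=C1N[C@H]2[C@H](CS[C@H]2CCCCCc2cn(Cc3cccc(F)c3)nn2)N1` differs from compound 3 by 3-fluorophenyl in place of 4-iodophenyl on a saturated chain carbon bound to an aromatic nitrogen. The three measured steps, each running between two limits, give no size to carry over to this change. The step that the limit leaves unreadable from compound 3 to compound 4 is expected to stay at the limit rather than yield a number. Compound 4 is estimated at 30000 nM, in the range 16000 nM to 100000 nM, most likely reported only as a limit.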

Compound 4, inhibition constant: > 16000 nM
Compound 4 ended at the assay's limit (the forecaster's own chance of this, stated with the estimate: 85%); the middle value is on the limit's open side.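

Going by these compounds alone, no step among compound 1, compound 2, compound 3 and compound 4 can be read, as all four stand at one limit: the limit of > 16000 nM in this assay, at which 4 of the 4 values shown sit. The compounds shown leave open whether any aryl group at this place gives a measurable inhibition constant.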